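Replacing 3,4-dimethoxyphenyl with pyridin-2-yl

The compounds below may be only part of what the source reports. "The series", "measured", "known", "first", "only" and "open" are said of these compounds alone.

Compound 1 `Cc1ccc(/C=C2/S/C(=N/c3ccccc3)N(Cc3ccncc3)C2=O)cc1`: 19700 nM
Compound 2 `CN(C)c1ccc(/C=C2/S/C(=N/c3ccccc3)N(Cc3ccncc3)C2=O)cc1`: 52600 nM
Compound 3 `COc1ccc(/C=C2/S/C(=N/c3ccccc3)N(Cc3ccncc3)C2=O)cc1OC`: 28900 nM

All three compounds were tested in a functional assay on HepG2 cells (Homo sapiens) for cytotoxicity, read by MTT assay, with a stated time of 48 h; a higher number here means a weaker inhibitor, a lower number a stronger inhibitor. Compound 3 stands close to the other two, with a 1.5-fold higher number from compound 1 to compound 3 (0.17 log units; within the scatter) and a 1.8-fold lower number from compound 2 to compound 3 (0.26 log units; within the scatter).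

Compound 4 `O=C1/C(=C\c2ccccn2)S/C(=N/c2ccccc2)N1Cc1ccncc1` differs from compound 3 in one group: pyridin-2-yl in place of 3,4-dimethoxyphenyl on a double-bonded chain carbon bound to a double-bonded ring carbon. Those two steps swap the same group, and the remaining step, a 2.7-fold higher number from compound 1 to compound 2 (0.43 log units; beyond the scatter), is modest. For the measured compounds named here, no measured compound has a hetero atom in the ring at this place, so the data favour no direction. No step beyond the scatter is expected in this assay. The estimated step is a 1.0-fold higher number from compound 3 to compound 4 (0.02 log units; within the scatter). For compound 4 the estimate is 30000 nM, with an expected range of 12000 nM to 75000 nM.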

Compound 4, half-maximal inhibitory concentration: 31000 nM
Compound 4: the middle estimate sits 1.0-fold (0.01 log units) below what was measured, and the stated range covers the measured number.
By their numbers in this assay, from the lowest: compounds 1, 3, 4 and 2 (each within the scatter of the next, the first and the last beyond it).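

In this assay, pyridin-2-yl, a ring with a hetero atom at this place, stays within the scatter of all three compounds with a carbon-only ring (a 1.1-fold higher number from compound 3 to compound 4 (0.03 log units; within the scatter)), (a 1.7-fold lower number from compound 2 to compound 4 (0.23 log units; within the scatter)) and (a 1.6-fold higher number from compound 1 to compound 4 (0.20 log units; within the scatter)). So, among these compounds, neither the ring nitrogen nor the loss of both methoxy groups gives a step beyond the scatter. Nothing available explains this result.

Going by these compounds, it remains open what pyridin-4-yl or a phenyl ring carrying a carboxylic acid would give at this place. On these data alone, a non-aromatic ring such as cyclohexyl also remains open.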